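The source may hold more compounds than are shown below. What is called first, only, known or untested is meant among the compounds shown, and "the series" means these compounds.

Compound 2 `Cn1ccc2ccc(-c3cc(Nc4cnccc4C(=O)NC4CCNC(=O)C4)cc4nccnc34)cc21` gives 69 nM in an assay for inhibition of 6-phosphofructo-2-kinase/fructose-2,6-bisphosphatase 3 (Homo sapiens), read by ADP-Glo, with a stated time of 2 h; a lower number here means a stronger inhibitor, a higher number a weaker inhibitor. Compound 1 `CN(C)C(=O)c1ccncc1Nc1cc(-c2ccc3ccn(C)c3c2)c2nccnc2c1` gives 499 nM in this assay.

Compound 2 holds the lowest of the two numbers, with compound 1 as the only other point, and the step of a 7.2-fold lower number from compound 1 to compound 2 (0.86 log units; beyond the scatter) shows that changing what sits on the carbonyl carbon can move the number. Compound 3 `CN1CC(NC(=O)c2ccncc2Nc2cc(-c3ccc4ccn(C)c4c3)c3nccnc3c2)CCC1=O` differs from compound 2 by 1-methyl-6-oxopiperidin-3-yl in place of 2-oxopiperidin-4-yl on an amide-type nitrogen. Going by the values given here, no measured step covers that change, so the expectation is that the step of a 1.7-fold higher number from compound 2 to compound 3 (0.24 log units; within the scatter) falls near or just beyond the scatter, toward a weaker inhibitor. Compound 3 is estimated at 120 nM, within 40 nM to 360 nM.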

Compound 3, half-maximal inhibitory concentration: 116 nM
The estimate for compound 3 lay 1.0-fold (0.01 log units) above the measured number; measured number inside the range.
By their numbers in this assay, from the lowest: compounds 2 and 3 (each within the scatter of the next); then compound 1.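

In this assay the step of a 1.7-fold higher number from compound 2 to compound 3 (0.23 log units; within the scatter) shows that on this amide-type nitrogen, 1-methyl-6-oxopiperidin-3-yl, with 0 hydrogen-bond donors, reads much like 2-oxopiperidin-4-yl, with 1. Going by these compounds alone, the step of a 4.3-fold lower number from compound 1 to compound 3 (0.63 log units; beyond the scatter) shows that 2-oxopiperidin-4-yl is not the only ring group whose number lies beyond the scatter from the dimethylamide. No supporting evidence explains either result.

From the compounds shown here alone, the change alters both the methyl group and the ring's attachment point, so their separate contributions stay open. Also open, going by these compounds, is how a piperidin-4-yl amine without the carbonyl would compare.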